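Adding a second chloro group to compound 3

The source may hold more compounds than are shown below. What is called first, only, known or untested is meant among the compounds shown, and "the series" means these compounds.

Measured in a functional assay on THP-1 cells (Homo sapiens) for activation, read by flow cytometry, with a stated time of 4 days; a lower number here means that less compound is needed, a higher number that more compound is needed for the effect:
- Compound 1 `Cc1ccc(C(=O)NCCC(=O)N[C@@H]2CCCc3ccccc32)cc1` gives 2700 nM
- Compound 2 `COc1ccc(C(=O)NCCC(=O)N[C@@H]2CCCc3ccccc32)cc1` gives 5100 nM
- Compound 3 `O=C(CCNC(=O)c1cccc(Cl)c1)N[C@@H]1CCCc2ccccc21` gives 6500 nM

Compound 3 stands at the high end of these numbers. The data show a 2.4-fold higher number from compound 1 to compound 3 (0.38 log units; beyond the scatter), while compound 3 cannot be told apart from compound 2, with a 1.3-fold higher number from compound 2 to compound 3 (0.11 log units; within the scatter).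

Compound 4 `O=C(CCNC(=O)c1ccc(Cl)c(Cl)c1)N[C@@H]1CCCc2ccccc21` has chloro in place of hydrogen on an aromatic carbon, ortho to a chloro group and para to a large group, which turns 3-chlorophenyl into 3,4-dichlorophenyl (chloro in place of hydrogen on an aromatic carbon). Within the data shown here, no measured step makes this exact change. The nearest evidence comes from changes on the same aromatic group: a 1.9-fold higher number from compound 1 to compound 2 (0.28 log units; within the scatter), along with the two steps above. All of them are small, so no step beyond the scatter is expected in this assay, at most a slight drift to a lower number. The expected change is a 1.4-fold lower number from compound 3 to compound 4 (0.16 log units; within the scatter). For compound 4 the estimate is 4500 nM, with an expected range from 1800 nM to 11000 nM.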

Compound 4, half-maximal effective concentration: 2500 nM
Estimate against measurement, compound 4: 1.8-fold (0.26 log units) above; the measured number falls inside the stated range.
By their numbers in this assay, from the lowest: compounds 4, 1, 2 and 3 (each within the scatter of the next, the first and the last beyond it).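

In this assay, the earlier changes swapped one group on the aromatic ring for another, whereas this one adds a single chlorine atom and keeps the first chloro group, and the number moves beyond the scatter (a 2.6-fold lower number from compound 3 to compound 4 (0.41 log units; beyond the scatter)). The 3,4-dichlorophenyl group also separates compound 4 from the 4-methoxyphenyl compound (a 2.0-fold lower number from compound 2 to compound 4 (0.31 log units; beyond the scatter)), yet it cannot be told apart from the 4-methylphenyl compound (a 1.1-fold lower number from compound 1 to compound 4 (0.03 log units; within the scatter)), so this one chlorine atom brings compound 3 back level with compound 1. Nothing shown here accounts for why the number moves.

The compounds shown leave open whether bromo, trifluoromethyl or an amine in place of the added chloro group would give a similar number. They also leave open whether the same step would hold on a longer chain between the two amide groups.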